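A few compounds are considered here, and "the series" means these few. Any claim that something is new, unique, unknown or untested is made for them only; others in the source may bear on it.

Working notes on a small set of brominated catechols. Going by the values given here, compound 1 `OCc1cc(Br)c(O)c(O)c1Br` is the only member with a number in a functional assay on HCT-116 cells (Homo sapiens) for cytotoxicity, read by MTT assay, with a stated time of 96 h (a lower number here means a stronger inhibitor, a higher number a weaker inhibitor), where compound 1 gives 21400 nM. Compound 2 `CCOCc1cc(O)c(O)c(Br)c1` was taken into the same assay, but in this assay compound 2 stands as "not determined" (no result reported), so there is no figure to place it against compound 1 or against any other member. Among the compounds with values here, no step between two measured compounds exists in this set, and no ordering can be drawn from it.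

The next member, compound 3 `CCOCc1cc(Br)c(O)c(O)c1Br`, differs from compound 2 in one place: bromo in place of hydrogen on an aromatic carbon. Without a measured step, the size of this change in this assay cannot be read from the data; a shift toward stronger inhibition is expected, but it may well stay within the scatter of repeated runs. Within the data shown here, the only anchor is compound 1, which carries the same pair of bromo groups on the shared core and gives 21400 nM in this assay. Compound 3 is therefore expected to fall near that level, estimated at 15000 nM, with a plausible range from 5000 nM to 45000 nM.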

Compound 3, half-maximal inhibitory concentration: 1540 nM
Compound 3: the middle estimate sits 9.7-fold (0.99 log units) above what was measured, and the stated range ends above it.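

In this assay, going by these compounds alone, the oxygen on a saturated carbon proves to be a sensitive place on the shared core: ethyl in place of hydrogen there gives a 14-fold lower number from compound 1 to compound 3 (1.14 log units; beyond the scatter) and is the first measured step. Compound 1 and compound 3 carry the same pair of bromo groups, so this step reads the change on that oxygen alone, with the rest of the structure held constant. On these data alone, compound 2 has no number, so the step from compound 2 to compound 3 cannot be read, and the size of the change from hydrogen to bromo on the aromatic carbon stays unknown. Nothing in the data shown accounts for the size of the ethyl step.

The compounds shown leave open whether a longer chain such as butyl on the same oxygen would carry the trend further or reverse it, and a single step cannot show which. Also open, as far as these compounds go, is how an amine or a carboxylic acid in place of the ethoxymethyl group would read in this assay on the same dibrominated catechol.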